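The source may hold more compounds than are shown below. What is called first, only, known or untested is meant among the compounds shown, and "the series" means these compounds.

Two analogues of a shared core have been tested in a functional assay on OVCAR-8 cells (Homo sapiens) for inhibition, read by sulforhodamine B assay, with a stated time of 48 h, tested at 10 uM; a lower number here means less inhibition, a higher number more inhibition at the concentration tested (going by the name of the read-out). Compound 1, `COc1ccc(-c2cn3ccnc3c(-c3ccc4ncn(C5CCCCC5)c4c3)n2)cc1`, gives 71.2% in this assay. Going by the values given here, compound 2, `O=Cc1ccc(-c2cn3ccnc3c(-c3ccc4ncn(C5CCCCC5)c4c3)n2)cc1`, gives 44%, the lower of the two numbers; the only step recorded so far, a number 27.2 percentage points lower from compound 1 to compound 2 (beyond the scatter), is a formyl in place of methoxy on an aromatic carbon. Compound 3, `c1cn2cc(-c3ccsc3)nc(-c3ccc4ncn(C5CCCCC5)c4c3)c2n1`, awaits measurement. It differs from compound 2 by thiophen-3-yl in place of 4-formylphenyl on an aromatic carbon. Among the compounds with values here, the single measured step bears only loosely on this change, since it concerns a substituent on the phenyl rather than the replacement of the whole aryl group, and it lowered inhibition modestly. Removing the formyl altogether may partly reverse that loss, so a modest rise is expected. Compound 3 is therefore estimated at 55%, with a range of 30% to 80%. That corresponds to an expected a number 11 percentage points higher from compound 2 to compound 3 (beyond the scatter).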

Compound 3, a percentage reported as inhibition, at one concentration (the size of the read-out at that concentration, not a potency): 12.1%
Compound 3: the middle estimate sits 42.9 percentage points above what was measured; the measured number lies below the stated range.
By their numbers in this assay, from the lowest: compound 3; then compound 2; then compound 1.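

Until now only a substituent on the phenyl had changed at this position; replacing the whole aryl group with thiophen-3-yl in this assay gives a number 31.9 percentage points lower from compound 2 to compound 3 (beyond the scatter), and the same exchange against 4-methoxyphenyl gives a number 59.1 percentage points lower from compound 1 to compound 3 (beyond the scatter). Losing the formyl therefore does not restore inhibition when the phenyl ring goes with it, and both phenyl compounds stand above compound 3. What lies behind this drop is not addressed by any evidence available here.

Still open, going by these compounds, is whether the loss belongs to the thiophene ring itself or to the missing substituent, since it is unknown whether an unsubstituted phenyl would read closer to compound 2 or to compound 3. Also open, on these data alone, is how a phenyl carrying an amine or a carboxylic acid would read in this assay.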